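Methylating the Ring Nitrogen Across Two Chain Lengths

This account rests on a few compounds, and the source may have more. Where it says the series, first, only, none or still open, it means among the compounds named here.

Compound 1 `CCCCCC(CCO)n1cnc2c(NC)ncnc21` carries a methylamino group on the shared core. In a functional assay on HCT-116 cells (Homo sapiens) for antiproliferative activity, read by MTT assay, with a stated time of 48 h (a lower number here means a stronger inhibitor, a higher number a weaker inhibitor), compound 1 reaches only a limit, > 50000 nM. Compound 2 `CCCCCC(CCO)n1cnc2c(N(C)C)ncnc21` differs from it by methyl in place of hydrogen on a nitrogen on an aromatic ring. In this assay compound 2 also stops at a limit, > 50000 nM. Compound 3 `CCCCCCC(CCO)n1cnc2c(NC)ncnc21` shares its core with compound 4 and differs from compound 1 by methyl in place of hydrogen on a saturated chain carbon, six bonds along the chain from an aromatic nitrogen. In this assay compound 3 again gives only a limit, > 50000 nM. The step that the two limits leave unreadable from compound 1 to compound 2 and the step that the two limits leave unreadable from compound 1 to compound 3 cannot be sized because of the limit of > 50000 nM in this assay, at which 3 of the 3 values shown sit. Compound 4 `CCCCCCC(CCO)n1cnc2c(N(C)C)ncnc21` has not been measured; it differs from compound 3 by methyl in place of hydrogen on a nitrogen on an aromatic ring, the same change that separates compound 2 from compound 1, at a place described in the same words. Since that change gave the unreadable step that the two limits leave unreadable from compound 1 to compound 2, the expected step to compound 4 is a step that the limit leaves unreadable from compound 3 to compound 4. Compound 3 itself shows only the limit > 50000 nM. Compound 4 is therefore estimated at 60000 nM, expected between 20000 nM and 200000 nM.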

Compound 4, half-maximal inhibitory concentration: > 50000 nM
Compound 4: only a limit was reported (the forecaster's own chance of this, stated with the estimate: 85%); the middle value lies beyond the limit too.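

In this assay, no new step can be read from compound 3 to compound 4 or from compound 2 to compound 4, because all the compounds stop at the same limit: the limit of > 50000 nM in this assay, at which 4 of the 4 values shown sit.

The compounds shown leave open how strong any of the four is, and whether either the methylamino to dimethylamino change or the added chain methyl alters activity at all.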